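The source may report more compounds than this note shows. Statements on the series, on what has been measured and on what is new or still open speak of the compounds shown alone.

Of the compounds shown here, three have been measured in an ADME assay for permeability; on this read-out higher numbers stand for higher permeability and lower numbers for lower permeability: compound 1 `CNC(=O)c1cc(C(=O)N[C@H]2CC[C@H](O)CC2)n([C@@H](C)c2ccc(Cl)cc2)n1` gives 180 nm/s, compound 2 `CNC(=O)c1cc(C(=O)N[C@H]2[C@@H]3C[C@H](O)C[C@@H]32)n([C@@H](C)c2cccc(Cl)c2)n1` gives 333 nm/s and compound 3 `CNC(=O)c1cc(C(=O)N[C@H]2[C@@H]3COC[C@@H]32)c([C@@H](C)c2ccccc2)o1` gives 200 nm/s. Compound 3 lies within the scatter of both others, so these numbers do not set it apart. Compound 4 `CNC(=O)c1cc(C(=O)N[C@H]2CC[C@H](O)CC2)c([C@@H](C)c2ccccc2)o1` keeps the core of compound 3 and changes one group on an amide-type nitrogen: a group of 7 heavy atoms (6 carbon, 1 oxygen; one six-membered non-aromatic ring of carbon only) in place of a group of 6 heavy atoms (5 carbon, 1 oxygen; one three-membered non-aromatic ring of carbon only, one five-membered non-aromatic ring with 1 hetero atom), on an amide-type nitrogen. Among the measured compounds shown here, no measured pair shows this change alone. Compound 1 carries the same 4-hydroxycyclohexyl on a different core and gives 180 nm/s, so only a modest shift seems likely. The expected step, a 1.3-fold lower number from compound 3 to compound 4 (0.12 log units; within the scatter), is a slight fall that stays within the scatter. The estimate for compound 4 is 150 nm/s, with an expected range of 80 nm/s to 280 nm/s.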

Compound 4, apparent permeability: 42 nm/s
Compound 4: middle estimate off by 3.6-fold (0.55 log units), on the high side; the measured number lies below the stated range.
By their numbers in this assay, from the lowest: compound 4; then compounds 1, 3 and 2 (each within the scatter of the next).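

Among the compounds shown here, the only step that can be read so far in this assay lies beyond the scatter: placing 4-hydroxycyclohexyl on the amide-type nitrogen gives a 4.8-fold lower number from compound 3 to compound 4 (0.68 log units; beyond the scatter). On the core of compound 3, then, the group at this position can clearly move the read-out. The entering group has 1 hydrogen-bond donor and the leaving group has 0, but their rings differ too, and no available data explain the fall.

A plain cyclohexyl on this nitrogen would help separate the role of the hydroxyl from that of the ring. From the compounds shown here alone, whether the same swap has a similar effect on the core of compound 1 remains open.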